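Cytotoxicity of three measured compounds and one yet untested

This account rests on a few compounds, and the source may have more. Where it says the series, first, only, none or still open, it means among the compounds named here.

Compound 1 `CC(C)Sc1nc(O)cc(C(C)c2ccccc2)n1` gives > 200000 nM in a functional assay on MT4 cells (Homo sapiens) for cytotoxicity (a higher number here means that more compound is tolerated, a lower number that less compound is tolerated), and this is a limit of the assay rather than a number.
Compound 2 `CCC(c1ccccc1)c1cc(O)nc(SC(C)C)n1` gives > 200000 nM in this assay, again a limit.
Compound 3 `CC(c1cc(O)nc(SC2CCCCC2)n1)c1c(Cl)cccc1Cl` gives > 200000 nM in this assay, once more a limit.

Among the measured compounds shown here, all three measured values sit at the limit of > 200000 nM in this assay, at which 3 of the 3 values shown sit, so no measured compound shows a numerical tolerated concentration. The change from compound 1 to compound 2 is methyl in place of hydrogen on a saturated chain carbon, two bonds along the chain from two aromatic carbons; the step it produced, a step that the two limits leave unreadable from compound 1 to compound 2, cannot be sized, since both compounds sit at the limit. The difference between the core of compound 1 and the core of compound 3 is not broken down here.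

Compound 4 `CCC(c1cc(O)nc(SC2CCCCC2)n1)c1c(Cl)cccc1Cl` has not yet been measured in this assay. It differs from compound 3 by methyl in place of hydrogen on a saturated chain carbon, two bonds along the chain from two aromatic carbons, the same change as that from compound 1 to compound 2, made at the same place on the chain.

The expectation for compound 4 rests on compound 3, which gives only a limit, and on the earlier pair, where the same change left both compounds at the limit of > 200000 nM in this assay, at which 3 of the 3 values shown sit. The step from compound 3 to compound 4 is therefore expected to be a step that the limit leaves unreadable from compound 3 to compound 4, meaning essentially no readable change. Compound 4 is estimated to give 250000 nM in this assay, most likely reported as a limit once more.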

Compound 4, half-maximal cytotoxic concentration: 200000 nM
The estimate for compound 4 lay 1.3-fold (0.10 log units) above the measured number, and the stated range covers the measured number.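

On the core of compound 3, methyl in place of hydrogen on a saturated chain carbon gave a number no higher from compound 3 to compound 4 (the limit leaves the size open) in this assay, and compound 4 gives 200000 nM, the only actual number among the compounds shown. Compound 3 gives > 200000 nM, which is a limit and not a number. The step therefore shows only that the change, carried from the core of compound 1 to the core of compound 3, brought no readable shift in tolerated concentration on either core; it does not show that the change has the same size on both, since neither step can be read and no pair offers two numbers to compare, with the values gathered at one limit: the limit of > 200000 nM in this assay, at which 3 of the 4 values shown sit.

The compounds shown leave open whether any change on this chain carbon would bring a number clearly under that limit, for instance a longer chain such as propyl in place of the methyl to ethyl change, or an amine or a carboxylic acid at the same place. They also leave open how far the group on the sulfur and the chlorines on the aromatic ring each contribute, as the cores of compound 1 and compound 3 differ in more than one place.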